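The compounds below may be only part of what the source reports. "The series", "measured", "known", "first", "only" and "open" are said of these compounds alone.

Compound 2, whose structure is `O=C1NCCN1c1ccc(S(=O)(=O)Nc2ccc(F)c(F)c2)cc1`, and compound 1, whose structure is `CCCCc1ccc(NS(=O)(=O)c2ccc(N3CCNC3=O)cc2)cc1`, share one core and differ only in the ring on the sulfonamide nitrogen. In a functional assay on MCF7 cells (Homo sapiens) for antiproliferative activity, read by sulforhodamine B assay, with a stated time of 48 h (on this read-out higher numbers stand for weaker inhibition and lower numbers for stronger inhibition), compound 2 gives 620 nM, and in this assay compound 1 gives 770 nM. Going by the values given here, these two numbers sit within the usual scatter of one another, so neither compound can be set above the other on the evidence so far; compound 2 is simply the one whose value is taken as the starting point here.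

Compound 3, whose structure is `O=C1NCCN1c1ccc(S(=O)(=O)Nc2cccc(Cl)c2)cc1`, is the next step. Its difference from compound 2 is 3-chlorophenyl in place of 3,4-difluorophenyl on a sulfonamide nitrogen. Among the compounds with values here, no pair of measured compounds shows what such a swap does to the numbers, so there is no measured step to lean on. Because the two measured compounds, with differently substituted phenyl rings, give values that differ by less than the scatter, the step from compound 2 to compound 3 is expected to be small as well, in no clear direction. Compound 3 is therefore estimated at 650 nM in this assay, within a range of 250 nM to 1700 nM, meaning an expected step of a 1.0-fold higher number from compound 2 to compound 3 (0.02 log units; within the scatter).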

Compound 3, half-maximal inhibitory concentration: 79 nM
The estimate for compound 3 lay 8.2-fold (0.92 log units) above the measured number; measured number below the stated range.
By their numbers in this assay, from the lowest: compound 3; then compounds 2 and 1 (each within the scatter of the next).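

In this assay, the ring on the sulfonamide nitrogen proves far more sensitive to change than the close values of compound 1 and compound 2 could reveal. Putting 3-chlorophenyl in place of 3,4-difluorophenyl gives a 7.8-fold lower number from compound 2 to compound 3 (0.89 log units; beyond the scatter), a step beyond the scatter, although the rest of the structure stays the same and both groups are a six-membered aromatic ring of carbon only, with no hydrogen-bond donors or acceptors and no net charge. So the gain comes from what is attached to this phenyl ring, yet no measurement shown here accounts for the size of the step.

This single swap removes both fluorines and adds a chlorine in one move, so the compounds shown cannot tell how much of the step belongs to gaining the chlorine and how much to losing the fluorines. They also leave open whether the gain is specific to chlorine or would also appear with 3-bromophenyl or 3-methylphenyl, and how a ring carrying an amine or a carboxylic acid would behave at this position.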